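The source may report more compounds than this note shows. Statements on the series, on what has been measured and on what is new or still open speak of the compounds shown alone.

Measured so far in a functional assay on A549 cells (Homo sapiens) for antiproliferative activity, read by MTT assay, with a stated time of 48 h; on this read-out lower numbers stand for stronger inhibition and higher numbers for weaker inhibition:

compound 1 `C/C(=C\CC/C(C)=C/CC[C@@H]1[C@@]2(C)CCC(=O)C(C)(C)[C@H]2CC[C@@]1(C)O)CC/C=C(\C)C(=O)OCc1cn(-c2ccc(F)cc2)nn1`: > 150000 nM
compound 2 `C/C(=C\CC/C(C)=C/CC[C@@H]1[C@@]2(C)CCC(=O)C(C)(C)[C@H]2CC[C@@]1(C)O)CC/C=C(\C)C(=O)OCc1cn(-c2ccc([N+](=O)[O-])cc2)nn1`: > 150000 nM

Compound 2 stands only at a limit of this assay, > 150000 nM, and no number is known for it. Compound 1 likewise sits at a limit, > 150000 nM. Within the data shown here, the one measured step, a step that the two limits leave unreadable from compound 1 to compound 2, has no readable size because both values sit at the limit of > 150000 nM in this assay, at which 2 of the 2 values shown sit; exchanging nitro for fluoro on the aromatic carbon therefore tells nothing about direction or magnitude.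

Compound 3 `C/C(=C\CC/C(C)=C/CC[C@@H]1[C@@]2(C)CCC(=O)C(C)(C)[C@H]2CC[C@@]1(C)O)CC/C=C(\C)C(=O)OCc1cn(-c2cccc(O)c2)nn1` is the next member. The change from compound 2 is 3-hydroxyphenyl in place of 4-nitrophenyl on an aromatic nitrogen. No measured step bears on this change in a readable way: the only step shown, a step that the two limits leave unreadable from compound 1 to compound 2, is itself unreadable, so the two values give no basis for expecting a step in either direction beyond the scatter.

On the numbers shown, compound 3 is expected near the same limit, at 150000 nM, with a range of 40000 nM to 400000 nM, and most likely reported again only as a limit. The step this estimate means, a number no higher from compound 2 to compound 3 (the limit leaves the size open), is expected to stay within the scatter.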

Compound 3, half-maximal inhibitory concentration: 42800 nM
Estimate against measurement, compound 3: 3.5-fold (0.54 log units) above, within the range that was stated.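

In this assay, the group on the aromatic nitrogen of the five-membered aromatic ring proves to be a place where a change can be read: 3-hydroxyphenyl in place of 4-nitrophenyl gives an at least 3.5-fold lower number from compound 2 to compound 3 (0.54 log units; beyond the scatter), and 3-hydroxyphenyl in place of 4-fluorophenyl gives an at least 3.5-fold lower number from compound 1 to compound 3 (0.54 log units; beyond the scatter). Compound 3 is the first member of the series with a number rather than a limit, so this position is now shown to bear on the read-out, which the unreadable step between the two earlier compounds could not show. Both new steps give only a minimum size because their starting values are limits and not numbers: the limit of > 150000 nM in this assay, at which 2 of the 3 values shown sit.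

The 3-hydroxyphenyl group differs from both earlier groups in its substituent and in where that substituent sits, and the compounds shown do not tell these two changes apart. From the compounds shown here alone, it also remains open whether an amine or a carboxylic acid in place of the hydroxyl, or a plain phenyl group, would give a number rather than a limit in this assay.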